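Swapping the nitrophenyl for a chlorophenyl: what to expect

The source may report more compounds than this note shows. Statements on the series, on what has been measured and on what is new or still open speak of the compounds shown alone.

In a functional assay on NCI-H460 cells (Homo sapiens) for cytotoxicity, read by sulforhodamine B assay (on this read-out higher numbers stand for lower toxicity in this test and lower numbers for higher toxicity in this test), compound 2 `CC1=CC[C@@H]([C@@](C)(O)CCCC(C)(C)NC(=S)N/N=C\c2ccc([N+](=O)[O-])cc2)CC1` gives only a limit, > 100000 nM. Compound 1 `CC1=CC[C@@H]([C@@](C)(O)CCCC(C)(C)NC(=S)N/N=C\c2ccc(N(C)C)cc2)CC1` likewise gives only a limit, namely > 100000 nM. For the measured compounds named here, the single comparison among the measured compounds is a step that the two limits leave unreadable from compound 1 to compound 2, and because both results sit at the same limit of > 100000 nM in this assay, at which 2 of the 2 values shown sit, the size of that step cannot be read. So compound 2 stands at the edge of what this assay can report, with nothing measurable above or below it.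

Compound 3 `CC1=CC[C@@H]([C@@](C)(O)CCCC(C)(C)NC(=S)N/N=C\c2ccccc2Cl)CC1` differs from compound 2 by 2-chlorophenyl in place of 4-nitrophenyl on a carbon with a double bond to nitrogen. No measured step speaks to this change: the one step shown is unreadable, and it concerns a different exchange on a different part of the ring. There is therefore no basis for expecting a shift in either direction beyond the scatter. The estimated step of a number no higher from compound 2 to compound 3 (the limit leaves the size open) is accordingly expected to be close to none. Compound 3 is expected to give about 100000 nM, with a range from 30000 nM to 300000 nM, and most likely again only a limit.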

Compound 3, concentration lethal to 50% of the cells: > 100000 nM
Compound 3: no number, only a limit; the forecaster's own chance of this, stated with the estimate: 70%; the middle value lies on the limit itself.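

The sizes of the steps from compound 2 to compound 3 and from compound 1 to compound 3 cannot be read, because compound 3 too gives only a limit in this assay: the limit of > 100000 nM in this assay, at which 3 of the 3 values shown sit.

The compounds shown leave open how toxic each of the three is to these cells, and whether 2-chlorophenyl, 4-nitrophenyl and 4-(dimethylamino)phenyl differ at all in this test.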